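The source may hold more compounds than are shown below. What is called first, only, known or untested is meant among the compounds shown, and "the series" means these compounds.

The measured compounds:
compound 1, `CC1=CC[C@H](C(C)(C)NC(=S)NN)CC1`: 900 nM
compound 2, `CC1=CC[C@H](C(C)(C)NC(=S)N/N=C/c2ccccc2[N+](=O)[O-])CC1`: 1200 nM

Both were tested in a functional assay on MCF7 cells (Homo sapiens) for inhibition, read by sulforhodamine B assay, with a stated time of 48 h; a lower number here means a stronger inhibitor of growth, a higher number a weaker inhibitor of growth. Compound 1 gives 900 nM, and compound 2 gives 1200 nM. These two numbers lie within the usual scatter of each other, so on the numbers shown compound 1 sits alongside compound 2 and neither stands apart from the other.

Compound 3, `CC1=CC[C@H](C(C)(C)NC(=S)N/N=C/c2ccco2)CC1`, has not yet been measured in this assay. It differs from compound 1 in one place: a group of 7 heavy atoms (5 carbon, 1 nitrogen, 1 oxygen; one five-membered aromatic ring with 1 hetero atom) in place of one nitrogen atom, on an amide-type nitrogen. The group that enters carries no hydrogen-bond donors and two hydrogen-bond acceptors, in place of the amino group, which carried one of each.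

Among the measured compounds shown here, no step between two measured compounds bears directly on this change. What the two measured values do show is that compound 2, which carries a larger group where compound 1 carries the amino group, gives a number within the scatter of compound 1. On that basis the expected step is a 1.1-fold higher number from compound 1 to compound 3 (0.05 log units; within the scatter), nothing beyond the scatter. For compound 3 the estimate in this assay is 1000 nM, with a range from 400 nM to 2500 nM.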

Compound 3, concentration for 50% growth inhibition: 9300 nM
The estimate for compound 3 lay 9.3-fold (0.97 log units) below the measured number; measured number above the stated range.
By their numbers in this assay, from the lowest: compounds 1 and 2 (each within the scatter of the next); then compound 3.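

In this assay, the result shows that this place, on an amide-type nitrogen whose other neighbour is the thiocarbonyl carbon, is not indifferent to the group it carries: putting the group with the five-membered aromatic ring in place of the amino group gives a 10-fold higher number from compound 1 to compound 3 (1.01 log units; beyond the scatter). Size of the entering group alone therefore does not settle the outcome, since compound 2, which also carries a larger group at this place, gives 1200 nM, whereas compound 3 gives 9300 nM. Nothing available explains why these two larger groups part in this way.

The compounds shown leave open whether the weaker growth inhibition of compound 3 follows from its five-membered ring, from the hetero atom in that ring, or from the absence of the nitro-bearing ring of compound 2. A thiophene ring, a plain phenyl ring or a pyridine ring at the same place would help to separate these readings, and a simple methyl group would show how the number responds without any ring there.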